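This account rests on a few compounds, and the source may have more. Where it says the series, first, only, none or still open, it means among the compounds named here.

Compound 1 `O=S(=O)(NCCCNc1nccc(-c2[nH]c(-c3ccccc3)nc2-c2ccc(F)c(O)c2)n1)c1ccc(F)cc1` is the starting point. In a functional assay on LOX IMVI cells (Homo sapiens) for cytotoxicity, read by MTT assay, with a stated time of 24 h (on this read-out lower numbers stand for stronger inhibition and higher numbers for weaker inhibition), compound 1 gives 19200 nM. Compound 2 `O=S(=O)(NCCCNc1nccc(-c2[nH]c(-c3ccccc3)nc2-c2ccc(F)c(O)c2)n1)c1ccc(C(F)(F)F)cc1` differs from it by trifluoromethyl in place of fluoro on an aromatic carbon; in this assay compound 2 gives 2450 nM, which is a 7.8-fold lower number from compound 1 to compound 2 (0.89 log units; beyond the scatter). Compound 3 `O=S(=O)(NCCCNc1nccc(-c2[nH]c(-c3ccccc3)nc2-c2ccc(Cl)c(O)c2)n1)c1ccc(F)cc1` differs from compound 1 by chloro in place of fluoro on an aromatic carbon; in this assay compound 3 gives 2300 nM, which is an 8.3-fold lower number from compound 1 to compound 3 (0.92 log units; beyond the scatter). The values of compound 2 and compound 3 lie within the usual scatter of each other. Compound 4 `O=S(=O)(NCCCNc1nccc(-c2[nH]c(-c3ccccc3)nc2-c2ccc(Cl)c(O)c2)n1)c1ccc(C(F)(F)F)cc1` differs from compound 3 by trifluoromethyl in place of fluoro on an aromatic carbon, the same change as before, at the same place. Compound 4 is expected to show a step of a 4.6-fold lower number from compound 3 to compound 4 (0.66 log units; beyond the scatter). This rests on the earlier step of a 7.8-fold lower number from compound 1 to compound 2 (0.89 log units; beyond the scatter), tempered because compound 3 already stands at 2300 nM and a second gain of full size is not certain. Compound 4 is estimated at 500 nM, with a likely range from 150 nM to 1500 nM.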

Compound 4, half-maximal inhibitory concentration: 10100 nM
Beside the measured number, compound 4's estimate is 20-fold (1.31 log units) below it; measured number above the stated range.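

The new step is a 4.4-fold higher number from compound 3 to compound 4 (0.64 log units; beyond the scatter), so trifluoromethyl in place of fluoro does not carry over from one core to the other, and its direction reverses: the same change on two cores in this assay, a 7.8-fold lower number (0.89 log units; beyond the scatter) from compound 1 to compound 2 and a 4.4-fold higher number (0.64 log units; beyond the scatter) from compound 3 to compound 4, 34-fold (1.54 log units) apart, beyond the scatter of two such steps

Chloro in place of fluoro also reverses direction once trifluoromethyl is present, with a 4.1-fold higher number from compound 2 to compound 4 (0.62 log units; beyond the scatter): the same change on two cores in this assay, an 8.3-fold lower number (0.92 log units; beyond the scatter) from compound 1 to compound 3 and a 4.1-fold higher number (0.62 log units; beyond the scatter) from compound 2 to compound 4, 34-fold (1.54 log units) apart, beyond the scatter of two such steps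

These four compounds show that the two changes do not simply add up in this assay, but they cannot show why, or whether the reversal extends to other groups.

Going by these compounds, it remains open whether a nitrile or methoxy in place of the 4-fluoro group, or bromo in place of chloro, would follow the first pattern or the second. On these data alone, it also remains open whether the reversal would persist with a longer chain.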